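A Methoxyphenyl Swap on a Shared Core

A few compounds are considered here, and "the series" means these few. Any claim that something is new, unique, unknown or untested is made for them only; others in the source may bear on it.

Compound 1 `O=c1c2ccccc2c(Cc2ccc(Cl)cc2)nn1C1CCCN(Cc2ccc(OCCCN3CCCCCC3)cc2)CC1`: 100 nM
Compound 2 `CN1CCC[C@@H]1Cn1nc(Cc2ccc(F)c(F)c2)c2ccccc2c1=O`: 200 nM

Of the compounds shown here, two have been measured in an assay for binding affinity to Alpha-1A adrenergic receptor (Homo sapiens); on this read-out lower numbers stand for stronger inhibition and higher numbers for weaker inhibition. Compound 1 `O=c1c2ccccc2c(Cc2ccc(Cl)cc2)nn1C1CCCN(Cc2ccc(OCCCN3CCCCCC3)cc2)CC1` gives 100 nM, and compound 2 `CN1CCC[C@@H]1Cn1nc(Cc2ccc(F)c(F)c2)c2ccccc2c1=O` gives 200 nM. Of the two numbers, that of compound 2 is the higher, yet the gap to compound 1 lies within the usual scatter of repeated measurements, so the two compounds cannot be separated on this evidence.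

The unmeasured compound 3 `COc1ccc(Cc2nn(C[C@H]3CCCN3C)c(=O)c3ccccc23)cc1` differs from compound 2 in one place: 4-methoxyphenyl in place of 3,4-difluorophenyl on a saturated chain carbon bound to an aromatic carbon. Among the compounds with values here, no measured pair shows this change, so nothing in the data tells how a 4-methoxyphenyl compares with a 3,4-difluorophenyl on a saturated chain carbon bound to an aromatic carbon, and the shared core is left untouched. The step expected a 1.3-fold higher number from compound 2 to compound 3 (0.10 log units; within the scatter) in this assay is therefore none beyond the scatter, in no particular direction. From the compounds shown here alone, compound 3 is estimated at 250 nM in this assay, with a range from 80 nM to 800 nM that is kept wide because the change itself is untested here.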

Compound 3, inhibition constant: 126 nM
Beside the measured number, compound 3's estimate is 2.0-fold (0.30 log units) above it; the measured number falls inside the stated range.
By their numbers in this assay, from the lowest: compounds 1, 3 and 2 (each within the scatter of the next).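

In this assay, within the data shown here, compounds 2 and 3 form the first pair that isolates a change on a saturated chain carbon bound to an aromatic carbon, and putting 4-methoxyphenyl in place of 3,4-difluorophenyl gives a 1.6-fold lower number from compound 2 to compound 3 (0.20 log units; within the scatter) without separating the two compounds. The exchange therefore replaces both fluorine atoms with a methoxy group, adding one hydrogen-bond acceptor by the count, yet produces no difference that can be distinguished from repeat measurement in this single pair. Nothing available explains this result or links it to any property of either group.

The compounds shown leave open whether a group of another kind at this position, such as a 4-hydroxyphenyl, a pyridine ring or a cyclohexyl ring, would move the number beyond the scatter. Compound 1 differs from compounds 2 and 3 in more than one place, so it offers no reading of this exchange, and whether 4-methoxyphenyl and 3,4-difluorophenyl would also read alike on the core of compound 1, with its longer chain ending in a seven-membered amine, remains an open question.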